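A few compounds are considered here, and "the series" means these few. Any claim that something is new, unique, unknown or untested is made for them only; others in the source may bear on it.

Of the compounds shown here, three built on one shared core have been measured in a functional assay on MGC-803 cells (Homo sapiens) for inhibition, read by MTT assay, with a stated time of 48 h; on this read-out higher numbers stand for weaker inhibition and lower numbers for stronger inhibition. Compound 1 `COc1ccc(CN(C(=O)CCCl)c2cc(OC)c(OC)c(OC)c2)cc1O` gives 140 nM in this assay. Compound 2 `COc1ccc(CN(C(C)=O)c2cc(OC)c(OC)c(OC)c2)cc1O` gives 79 nM. Compound 3 `COc1ccc(CN(C(=O)C[Se]C#N)c2cc(OC)c(OC)c(OC)c2)cc1O` gives 270 nM, the highest of the three numbers; its nearest neighbour is compound 1, with a 1.9-fold higher number from compound 1 to compound 3 (0.29 log units; within the scatter), and its furthest is compound 2, with a 3.4-fold higher number from compound 2 to compound 3 (0.53 log units; beyond the scatter), the only gap in this set that goes beyond the scatter. Compound 4 `C=CC(=O)N(Cc1ccc(OC)c(O)c1)c1cc(OC)c(OC)c(OC)c1` has not yet been measured. It differs from compound 3 in one place: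
a group of 2 heavy atoms (2 carbon; no ring) in place of a group of 4 heavy atoms (2 carbon, 1 nitrogen, 1 selenium; no ring), on a carbonyl carbon
All three measured steps concern what sits on the saturated chain carbon bound to the carbonyl carbon, so each bears on this change. Between compounds 1 and 2 that change gave a 1.8-fold lower number from compound 1 to compound 2 (0.25 log units; within the scatter), while the two steps that put the selenium-containing group into compound 3 gave a 1.9-fold higher number from compound 1 to compound 3 (0.29 log units; within the scatter) and a 3.4-fold higher number from compound 2 to compound 3 (0.53 log units; beyond the scatter). The change to compound 4 takes that group out again, running opposite to those two steps, so a modestly lower number is expected, of about the size a 2.3-fold lower number from compound 3 to compound 4 (0.35 log units; beyond the scatter). For compound 4 the estimate in this assay is 120 nM, with a range from 50 nM to 300 nM.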

Compound 4, half-maximal inhibitory concentration: 62 nM
For compound 4 the middle estimate is 1.9-fold (0.29 log units) above the measured one; the range from low to high includes it.
By their numbers in this assay, from the lowest: compounds 4, 2, 1 and 3 (each within the scatter of the next, the first and the last beyond it).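

Putting vinyl on the carbonyl carbon in place of the selenium-containing group gives a 4.4-fold lower number from compound 3 to compound 4 (0.64 log units; beyond the scatter) in this assay and so confirms the direction seen when methyl stood in that place. Vinyl and methyl themselves cannot be told apart at this position, with a 1.3-fold lower number from compound 2 to compound 4 (0.11 log units; within the scatter) and the two compounds lying within the usual scatter of each other, so the double bond of vinyl shows no measurable difference from methyl here. The step to vinyl from 2-chloroethyl, a 2.3-fold lower number from compound 1 to compound 4 (0.35 log units; beyond the scatter), does go beyond the scatter, even though the step from that same group to the smaller chain end of compound 2 stayed within it, which makes vinyl and methyl a close pair at the low end of this set, with the selenium-containing group clearly above them.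

As far as these compounds go, whether a propyl chain, a phenyl ring or an aminomethyl group on the carbonyl carbon would fall with vinyl and methyl or with the selenium-containing group remains open. Nothing given here explains why these groups differ in this way.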